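Ethoxycarbonyl to carboxy: an unmeasured step in growth inhibition

The source may hold more compounds than are shown below. What is called first, only, known or untested is meant among the compounds shown, and "the series" means these compounds.

Compound 2 `CCOC(=O)/C=C/c1ccncc1-c1ccc2cc[nH]c2c1` gives 5740 nM in a functional assay on A549 cells (Homo sapiens) for inhibition, read by sulforhodamine B assay, with a stated time of 72 h (a higher number here means a weaker inhibitor of growth, a lower number a stronger inhibitor of growth), on its own core. Compound 1 `CNC(=O)/C=C/c1ccncc1-c1ccc2ccccc2c1` gives 6620 nM on a different core, and these two values lie within the scatter of each other. Compound 3 `O=C(O)/C=C/c1ccncc1-c1ccc2ccccc2c1` is recorded as > 10000 nM and that is a limit, not a number.

Compound 4 `O=C(O)/C=C/c1ccncc1-c1ccc2cc[nH]c2c1` is the unmeasured partner of compound 2. The change is hydrogen in place of ethyl on an oxygen next to a carbonyl group with hydrogen in place of ethyl on an oxygen next to a carbonyl group, so that ethoxycarbonyl becomes carboxy.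

For the measured compounds named here, one measured step bears on this. The step of an at least 1.5-fold higher number from compound 1 to compound 3 (0.17 log units; that floor lies within the scatter) also ends in a carboxy group, although it starts from methylamino rather than ethoxy and sits on the other core. Its size is known only as a floor, so it gives a direction and no firm magnitude. On that single precedent, a move towards a weaker inhibitor of growth is expected, and the estimated change is a 2.1-fold higher number from compound 2 to compound 4 (0.32 log units; beyond the scatter) in this direction. For compound 4 the estimate is 12000 nM with an expected range from 7000 nM to 25000 nM in this assay and a report of only a limit is quite possible.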

Compound 4, concentration for 50% growth inhibition: > 10000 nM
Compound 4 was reported as a limit; the forecaster's own chance of this, stated with the estimate: 60%; the middle value is on the limit's open side.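

In this assay compound 4 is reported as > 10000 nM, which is a limit and not a number. This gives the carboxy group a reading on the core of compound 2, whereas the earlier carboxy reading came from compound 3 on another core and from a methylamino starting point. The step is an at least 1.7-fold higher number from compound 2 to compound 4 (0.24 log units; that floor lies within the scatter), so the change from ethoxycarbonyl to carboxy points in the same direction on this core as on the other, but its floor does not leave the scatter and no firm size can be stated, and both carboxy compounds are now reported only as a limit: the limit of > 10000 nM in this assay, at which 2 of the 4 values shown sit.

The compounds shown leave open how large the step from ethoxycarbonyl to carboxy really is on either core, and so whether the two cores respond to it alike. They also leave open how a longer chain such as butoxy, or an amine such as dimethylamino, would read in place of ethoxy on the core of compound 2.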